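Propargyl amide series: whole-animal toxicity in the mouse

The source may hold more compounds than are shown below. What is called first, only, known or untested is meant among the compounds shown, and "the series" means these compounds.

Measured so far:
compound 1 `COc1ccc(/C(C)=C(/C)C(=O)NC2CC2)cc1`: 300 mg/kg
compound 2 `C#CCNC(=O)/C(C)=C(\C)c1ccc(C)cc1`: 120 mg/kg

In a toxicity assay on the whole organism (strain Icem-CET (SPF Caw)) for cytotoxicity, with Mus musculus as the target (a lower number here means that less compound is needed, a higher number that more compound is needed for the effect), compound 2 gives 120 mg/kg, the lower of the two numbers. Compound 1 gives 300 mg/kg, a gap beyond the scatter. For the measured compounds named here, no pair of measured compounds differs in a single place, so no step size has been seen directly.

Compound 3 `C#CCNC(=O)/C(C)=C(\C)c1ccccc1` differs from compound 2 by hydrogen in place of methyl on an aromatic carbon: a methyl leaves and a hydrogen enters on an aromatic carbon para to a large group. With nothing comparable measured, the expected step in this assay is small, none beyond the scatter, if anything toward a slightly higher number. Compound 3 is therefore expected at 150 mg/kg, within 60 mg/kg to 400 mg/kg. The expected step is a 1.3-fold higher number from compound 2 to compound 3 (0.10 log units; within the scatter).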

Compound 3, dose for half-maximal effect: 150 mg/kg
For compound 3 middle estimate and measured number coincide at the digits printed; the measured number falls inside the stated range.
By their numbers in this assay, from the lowest: compounds 2, 3 and 1 (each within the scatter of the next, the first and the last beyond it).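

In this assay, for the compounds shown here, the first comparison that differs in a single place gives a 1.3-fold higher number from compound 2 to compound 3 (0.10 log units; within the scatter) for hydrogen in place of methyl on an aromatic carbon para to a large group. At this position, the methyl can be removed without a change beyond the scatter. No measurement bears on the reason for this result.

Still open, going by these compounds, is whether another group here, such as an amine or a carboxylic acid, would shift the number beyond the scatter. Compound 1 differs from compound 2 and compound 3 in more than one place, leaving the contribution of the propargyl amide unresolved.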